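The source may hold more compounds than are shown below. What is called first, only, known or untested is meant among the compounds shown, and "the series" means these compounds.

Three compounds have been measured in a functional assay on the whole organism (strain NMRI) with Mus musculus as the target, with a stated time of 4 h; on this read-out lower numbers stand for an effect already at smaller amounts and higher numbers for an effect only at larger amounts of compound:
compound 1, `COc1ccc(Cn2cc(CO/N=C/c3c(-c4ccccc4)nc4c(C)cccn34)nn2)cc1`, gives 100 mg/kg
compound 2, `Cc1cccn2c(/C=N/OCc3cn(Cc4ccc(C#N)cc4)nn3)c(-c3ccccc3)nc12`, gives 40 mg/kg
compound 3, `COc1ccc(Cn2cc(CO/N=C/c3c(-c4ccccc4)nc4ccc(Br)cn34)nn2)cc1`, gives 40 mg/kg

Compound 1 and compound 2 share one core and differ in a single place: cyano in place of methoxy on an aromatic carbon. This brought a 2.5-fold lower number from compound 1 to compound 2 (0.40 log units; beyond the scatter), so a smaller dose of compound 2 was enough for the effect. Compound 3 carries another core; how the core of compound 1 and the core of compound 3 differ is not broken down here. Compound 3 and compound 2 give the same number at the digits reported, which lies within the usual scatter, so no order between them can be read.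

The unmeasured compound 4, `N#Cc1ccc(Cn2cc(CO/N=C/c3c(-c4ccccc4)nc4ccc(Br)cn34)nn2)cc1`, stands to compound 3 as compound 2 stands to compound 1: cyano in place of methoxy on an aromatic carbon. The place is described in the same words both times, so this is the same change made on a different core. Because a 2.5-fold lower number from compound 1 to compound 2 (0.40 log units; beyond the scatter) was seen once, a step in the same direction is expected for compound 4, though a single example on one core is a thin basis. For compound 4 the expected step is a 2.0-fold lower number from compound 3 to compound 4 (0.30 log units; within the scatter). Compound 4 is estimated at 20 mg/kg in this assay, between 8 mg/kg and 50 mg/kg.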

Compound 4, minimum effective dose: 20 mg/kg
Compound 4: the middle estimate sits on the measured number at the digits printed; measured number inside the range.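

Putting cyano in place of methoxy on the core of compound 3 gives, in this assay, a 2.0-fold lower number from compound 3 to compound 4 (0.30 log units; within the scatter), so this step taken alone does not separate the two compounds. Set beside the same change on the core of compound 1, the two steps agree: the same change on two cores in this assay, a 2.5-fold lower number (0.40 log units; beyond the scatter) from compound 1 to compound 2 and a 2.0-fold lower number (0.30 log units; within the scatter) from compound 3 to compound 4, 1.3-fold (0.10 log units) apart, within the scatter of two such steps This shows that the change gave a result of similar size and the same direction on both cores, but it rests on only two pairs, one of them within the scatter, and it does not show why the number moves or whether the same would hold on any further core.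

Only 4-methoxybenzyl and 4-cyanobenzyl appear among the compounds shown, so what an amine, a carboxylic acid or a longer chain in that place would give stays open. The effect of the core alone also stays open, as no pair shown isolates a single change on it.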